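The compounds below may be only part of what the source reports. "The series", "measured", "known", "first", "only" and "open" are said of these compounds alone.

Measured compounds:
Compound 1 `COc1cccc(Sc2c(NS(=O)(=O)c3ccc(C(C)(C)C)cc3)noc2CCCCC=O)c1`: 20 nM
Compound 2 `COc1cccc(Sc2c(NS(=O)(=O)c3ccc(C(C)(C)C)cc3)noc2CO)c1`: 560 nM

Among the measured compounds shown here, in an assay on COS-7 cells for displacement of a labelled ligand from Endothelin receptor type B (Sus scrofa) (on this read-out higher numbers stand for weaker inhibition and lower numbers for stronger inhibition), compound 2 stands at the highest of the two numbers, and the only step measured, a 28-fold higher number from compound 1 to compound 2 (1.45 log units; beyond the scatter), is large. Compound 3 `COc1cccc(Sc2c(NS(=O)(=O)c3ccc(C(C)(C)C)cc3)noc2CCCC(N)=O)c1` differs from compound 2 by 2-carbamoylethyl in place of hydroxy on a saturated chain carbon bound to an aromatic carbon; cut one bond further out, the same difference reads hydroxymethyl to 3-carbamoylpropyl. Going by these compounds, this change runs back toward the longer chain of compound 1, so the step from compound 1 to compound 2 is the one that bears on it; a step of the opposite direction, an 8.0-fold lower number from compound 2 to compound 3 (0.90 log units; beyond the scatter), is expected, though the carbamoyl end is untested. Compound 3 is estimated at 70 nM, within 15 nM to 300 nM.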

Compound 3, half-maximal inhibitory concentration: 240 nM
The estimate for compound 3 lay 3.4-fold (0.54 log units) below the measured number; the measured number falls inside the stated range.
By their numbers in this assay, from the lowest: compound 1; then compound 3; then compound 2.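

In this assay, hydroxymethyl to 3-carbamoylpropyl gives a 2.3-fold lower number from compound 2 to compound 3 (0.37 log units; beyond the scatter) as a modest step, whereas the change at the chain end gives a 12-fold higher number from compound 1 to compound 3 (1.08 log units; beyond the scatter) as a large one. The longer chain therefore does not by itself bring back the number of compound 1, and what ends the chain also appears to count, although compound 1 and compound 3 differ in both chain length and end group. No measurement at hand explains these steps.

Length and end group remain unseparated here. A carboxylic acid or primary amine on the same chain, or a plain pentyl chain, would help to tell them apart.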